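A few compounds are considered here, and "the series" means these few. Any claim that something is new, unique, unknown or untested is made for them only; others in the source may bear on it.

Compound 1 `COc1cc(-c2nn(-c3cccc(NC(=O)Nc4cc(C(F)(F)F)cc(C(F)(F)F)c4)c3)cc2-c2ccncc2)ccc1Cl`: in a functional assay on ACHN cells (Homo sapiens) for inhibition, read by sulforhodamine B assay, with a stated time of 48 h (on this read-out higher numbers stand for lower toxicity in this test and lower numbers for higher toxicity in this test), compound 1 gives > 50000 nM, which is a limit of the assay.
Compound 2 `COc1cc(-c2nn(-c3cccc(NC(=O)c4cccc(C(F)(F)F)c4)c3)cc2-c2ccncc2)ccc1Cl`: in this assay compound 2 gives > 50000 nM, also a limit.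
Compound 3 `O=C(Nc1cccc(-n2cc(-c3ccncc3)c(-c3ccc(Cl)c(O)c3)n2)c1)Nc1ccc(Cl)c(Cl)c1`: in this assay compound 3 gives > 32500 nM, again a limit.

Compound 2 therefore stands only at a limit, with no number of its own; the two other values shown are limits as well, one at the limit of > 32500 nM in this assay, at which 1 of the 3 values shown sits, and two at the limit of > 50000 nM in this assay, at which 2 of the 3 values shown sit. Compound 4 `COc1cc(-c2nn(-c3cccc(NC(=O)Nc4cccc(C(F)(F)F)c4)c3)cc2-c2ccncc2)ccc1Cl` differs from compound 2 by (3-(trifluoromethyl)phenyl)amino in place of 3-(trifluoromethyl)phenyl on a carbonyl carbon. For the measured compounds named here, no measured pair shows this change, and nothing among the values shown points to a step beyond the scatter in either direction in this assay. The expectation is therefore that compound 4 again reaches only a limit in this assay, with an estimated step from compound 2 of a number no higher from compound 2 to compound 4 (the limit leaves the size open). The estimate for compound 4 is 50000 nM, ranging from 15000 nM to 50000 nM.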

Compound 4, concentration lethal to 50% of the cells: > 50000 nM
Compound 4: only a limit was reported; the forecaster's own chance of this, stated with the estimate: 80%; the middle value sits exactly at the limit.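

In this assay, for the compounds shown here, compound 4 gives > 50000 nM, again a limit of the assay, so no step from compound 1 or compound 2 to compound 4 can be read. How far any of these compounds lies past its limit in this assay stays open, and with it any effect of the changes between them.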